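The source may hold more compounds than are shown below. What is called first, only, known or untested is meant among the compounds shown, and "the series" means these compounds.

Compound 1 `COc1ccc(C2SCC(=O)N2NC(=O)CNC(=O)c2ccccc2)cc1` gives 1.85 in a physicochemical assay for lipophilicity; a lower number here means a more polar compound, a higher number a more lipophilic compound. Compound 2 `COc1cc(C2SCC(=O)N2NC(=O)CNC(=O)c2ccccc2)cc(OC)c1OC` gives 1.65 in this assay. Compound 3 `O=C(CNC(=O)c1ccccc1)NN1C(=O)CSC1c1cccc(Cl)c1` gives 2.8 in this assay.

For the measured compounds named here, compound 3 stands highest of the three numbers measured so far. Its nearest neighbour is compound 1, and the step of a number 0.95 log units higher from compound 1 to compound 3 (beyond the scatter) lies beyond the scatter. Compound 2 lies further away still, its value falling below that of compound 1.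

Compound 4 `O=C(CNC(=O)c1ccccc1)NN1C(=O)CSC1c1ccccc1Cl` has not yet been measured. It differs from compound 3 in one place: 2-chlorophenyl in place of 3-chlorophenyl on a saturated ring carbon. Going by the values given here, none of the measured steps bears directly on this change; the only step measured, from compound 1 to compound 3, exchanges one group for another of different composition, whereas here the same atoms are joined differently. Among the compounds with values here, with no relevant step to draw on, the expected change in this assay is none beyond the scatter, so for compound 4 the estimated step is a number 0.10 log units lower from compound 3 to compound 4 (within the scatter). Compound 4 is therefore expected to give about 2.7 in this assay, within a range from 2.4 to 3.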

Compound 4, partition coefficient: 2.3
Estimate against measurement, compound 4: 0.40 log units above; the whole stated range lies above it.
By their numbers in this assay, from the lowest: compounds 2 and 1 (each within the scatter of the next); then compound 4; then compound 3.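

Compound 4 shows that in this assay it is not only the presence of chlorine on the phenyl group at this saturated ring carbon that counts, but also where it sits: with the same atoms joined differently, 2-chlorophenyl in place of 3-chlorophenyl gives a clear change (a number 0.50 log units lower from compound 3 to compound 4 (beyond the scatter)). The exchange of 4-methoxyphenyl for a chlorophenyl group therefore has no single size here, since 2-chlorophenyl gives a smaller rise (a number 0.45 log units higher from compound 1 to compound 4 (beyond the scatter)) than 3-chlorophenyl (a number 0.95 log units higher from compound 1 to compound 3 (beyond the scatter)). Nothing available explains why the two chlorophenyl groups differ.

The compounds shown leave open where 4-chlorophenyl would fall relative to 2-chlorophenyl and 3-chlorophenyl. They also leave open whether moving another group around this phenyl ring, such as fluorine or a carboxylic acid, would change the number to a similar extent.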